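A few compounds are considered here, and "the series" means these few. Any claim that something is new, unique, unknown or untested is made for them only; others in the source may bear on it.

In an assay on COS-7 cells for displacement of a labelled ligand from 5-hydroxytryptamine receptor 4 (Homo sapiens), read by scintillation counting, with a stated time of 30 min (a higher number here means a weaker inhibitor, a lower number a stronger inhibitor), compound 1 `COc1cc(N)c(Cl)cc1C(=O)N[C@H]1CCN(CC2CCN(C(=S)C(C)C)CC2)C[C@H]1OC` gives 155 nM, the lowest of the three numbers recorded. Compound 2 `CCC(=O)N1CCC(CCN2CC[C@H](NC(=O)c3cc(Cl)c(N)cc3OC)[C@H](OC)C2)CC1` gives 805 nM, and compound 3 `COc1cc(N)c(Cl)cc1C(=O)N[C@H]1CCN(CCCn2cccc2)C[C@H]1OC` gives 648 nM. Compound 4 `COc1cc(N)c(Cl)cc1C(=O)N[C@H]1CCN(CC2CCN(C(=O)N(C)C)CC2)C[C@H]1OC` differs from compound 1 by a group of 5 heavy atoms (3 carbon, 1 nitrogen, 1 oxygen; no ring) in place of a group of 5 heavy atoms (4 carbon, 1 sulfur; no ring), on an amine nitrogen in a ring. The step that bears most on this change is a 5.2-fold higher number from compound 1 to compound 2 (0.72 log units; beyond the scatter), in which the sulfur-bearing group likewise gave way to a carbonyl, though other changes came with it; the step of a 4.2-fold higher number from compound 1 to compound 3 (0.62 log units; beyond the scatter) replaces the same region with an unrelated ring and is less informative. Both measured steps moved away from compound 1 toward weaker binding, so a modest rise in this assay is expected, with the expected step being a 2.6-fold higher number from compound 1 to compound 4 (0.41 log units; beyond the scatter). Compound 4 is therefore expected to give 400 nM, within a range from 150 nM to 1100 nM.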

Compound 4, half-maximal inhibitory concentration: 52 nM
Compound 4: the middle estimate sits 7.7-fold (0.89 log units) above what was measured; measured number outside the range, below it.
By their numbers in this assay, from the lowest: compound 4; then compound 1; then compounds 3 and 2 (each within the scatter of the next).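

In this assay the dimethylcarbamoyl group on the ring amine nitrogen gave a 3.0-fold lower number from compound 1 to compound 4 (0.47 log units; beyond the scatter) in place of the sulfur-bearing group, so a carbonyl at this position can lower the number rather than raise it. With a 12-fold lower number from compound 3 to compound 4 (1.10 log units; beyond the scatter) and a 15-fold lower number from compound 2 to compound 4 (1.19 log units; beyond the scatter) as well, compound 4 stands as the strongest of the four, beyond the scatter from each. Nothing shown here explains this change. From the compounds shown here alone, it remains open whether the gain follows the carbonyl oxygen or the dimethylamino nitrogen. An isobutyryl or a dimethylthiocarbamoyl group on the same nitrogen would separate the two.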